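Pyrazole attachment on a fused core: notes toward compound 4

The source may report more compounds than this note shows. Statements on the series, on what has been measured and on what is new or still open speak of the compounds shown alone.

Measured so far in a functional assay on CHO cells for agonist activity at Alpha-1A adrenergic receptor (Homo sapiens), read by FLIPR and calcium flux; on this read-out lower numbers stand for an effect already at smaller amounts and higher numbers for an effect only at larger amounts of compound:
compound 1 `c1cc(-c2ccn[nH]2)c2c(c1)C(c1ncc[nH]1)CC2` gives 52 nM
compound 2 `c1ccc2c(c1)CCC2c1ncc[nH]1` gives 473 nM
compound 3 `c1ccc2c(c1)CCCC2c1ncc[nH]1` gives 385 nM

Compound 1 holds the lowest number of the three in this assay; compound 3 and compound 2 both lie beyond the scatter above it. Among the compounds with values here, the only step that isolates a single change is a 9.1-fold higher number from compound 1 to compound 2 (0.96 log units; beyond the scatter), hydrogen in place of 1H-pyrazol-5-yl on an aromatic carbon, so the 1H-pyrazol-5-yl group accounts for most of what separates compound 1 from compound 2 in this assay.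

Compound 4 `c1cc(-c2cn[nH]c2)c2c(c1)C(c1ncc[nH]1)CC2` keeps the same atoms joined differently: 1H-pyrazol-4-yl in place of 1H-pyrazol-5-yl on an aromatic carbon. Within the data shown here, no measured step moves the attachment point of this ring, so the direction of the change is not settled by the data; the outer bound for a loss is set by a 9.1-fold higher number from compound 1 to compound 2 (0.96 log units; beyond the scatter), the case where the ring is gone altogether. Compound 4 is therefore expected to sit between those two outcomes, a moderate rise in the number a 2.5-fold higher number from compound 1 to compound 4 (0.40 log units; beyond the scatter). The estimate for compound 4 is 130 nM, with a range from 45 nM to 400 nM.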

Compound 4, half-maximal effective concentration: 14 nM
For compound 4 the middle estimate is 9.3-fold (0.97 log units) above the measured one; measured number outside the range, below it.
By their numbers in this assay, from the lowest: compound 4; then compound 1; then compounds 3 and 2 (each within the scatter of the next).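

In this assay, the attachment point of the pyrazole counts on its own at this aromatic carbon: 1H-pyrazol-4-yl in place of 1H-pyrazol-5-yl, with the atom and donor and acceptor counts unchanged, gives a 3.7-fold lower number from compound 1 to compound 4 (0.57 log units; beyond the scatter). Within the data shown here, the earlier compounds showed only that a 1H-pyrazol-5-yl group at this position lowers the number relative to hydrogen, while 1H-pyrazol-4-yl in place of hydrogen gives a larger step, a 34-fold lower number from compound 2 to compound 4 (1.53 log units; beyond the scatter). The gain at this position therefore depends on how the ring is attached, not only on its presence.

Still open, going by these compounds, is whether an amine, a carboxylic acid or an N-methylpyrazole at the same aromatic carbon would keep the number this low, and whether the step carries over to the core of compound 3. Nothing at hand gives a reason for the difference between the two attachment points.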